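The compounds below may be only part of what the source reports. "The series", "measured", "known", "first", "only" and "open" are said of these compounds alone.

Measured so far in an assay on isolated protein for inhibition of protein deacetylase HDAC6 (Homo sapiens); on this read-out lower numbers stand for stronger inhibition and higher numbers for weaker inhibition:
Compound 1 `O=C(c1ccc(-c2ccccc2)s1)C(F)(F)F` gives 170 nM.
Compound 2 `COc1ccc(-c2ccc(C(=O)C(F)(F)F)s2)cc1` gives > 1000 nM, which is a limit of this assay and not a number.
Compound 3 `COc1ccccc1-c1ccc(C(=O)C(F)(F)F)s1` gives 6300 nM.

Compound 2 therefore stands only at the limit of > 1000 nM in this assay, at which 1 of the 3 values shown sits; no number is known for it, so the step of an at least 5.8-fold higher number from compound 1 to compound 2 (0.76 log units; beyond the scatter) is itself only a bound. The related change a 37-fold higher number from compound 1 to compound 3 (1.57 log units; beyond the scatter), a methoxy in place of hydrogen elsewhere on the shared core, gave a clear loss.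

Compound 4 `N#Cc1ccc(-c2ccc(C(=O)C(F)(F)F)s2)cc1` differs from compound 2 by cyano in place of methoxy on an aromatic carbon. For the measured compounds named here, no measured step involves a cyano group, so the two measured steps bear on it only indirectly: both show that a methoxy added to compound 1 weakens binding, and compound 4 removes that methoxy while placing a different group on the same aromatic carbon. Whether the cyano brings potency back toward compound 1 or leaves it near compound 2 cannot be read from the series; in this assay a modest change in either direction is possible, and a further limit is about as likely as a number.

Compound 4 is expected at about 1500 nM, with a range of 300 nM to 8000 nM. As far as these compounds go, the step that the limit leaves unreadable from compound 2 to compound 4 is accordingly estimated to be small, and because compound 2 carries only the limit of > 1000 nM in this assay, at which 1 of the 3 values shown sits, its direction stays open.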

Compound 4, half-maximal inhibitory concentration: 41 nM
Beside the measured number, compound 4's estimate is 37-fold (1.56 log units) above it; the measured number lies below the stated range.
By their numbers in this assay, from the lowest: compound 4; then compound 1; then compound 3.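

Cyano in place of hydrogen on the aromatic carbon para to a large group gives a 4.1-fold lower number from compound 1 to compound 4 (0.62 log units; beyond the scatter) in this assay, the first change from compound 1 in this series that lowers the number rather than raises it, so a group at this place does not in itself cost inhibition. At the same place, the exchange of methoxy for cyano gives an at least 24-fold lower number from compound 2 to compound 4 (1.38 log units; beyond the scatter), which shows that the identity of the group matters here, as the two groups have the same heavy-atom count and the same hydrogen-bond acceptor count. The true size of this step cannot be read, and it remains a bound, because compound 2 carries only a limit and not a number: the limit of > 1000 nM in this assay, at which 1 of the 4 values shown sits.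

Only hydrogen, methoxy and cyano are shown at this place, so it remains open whether an amine, a carboxylic acid or a chlorine atom there would follow cyano or methoxy. As far as these compounds go, it also remains open whether cyano on the aromatic carbon that carries methoxy in compound 3 would lower the number as it does in compound 4.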